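Swapping trifluoromethyl for phenyl on a shared core

A few compounds are considered here, and "the series" means these few. Any claim that something is new, unique, unknown or untested is made for them only; others in the source may bear on it.

Measured in an ADME assay on NCI-H226 cells (Homo sapiens) for cytotoxicity, read by MTT assay; a lower number here means a stronger inhibitor, a higher number a weaker inhibitor:
- Compound 1 `O/N=C(\COc1cccc2ccccc12)c1ccc(F)cc1`: > 50000 nM
- Compound 2 `O/N=C(\COc1cccc2ccccc12)c1ccc(C(F)(F)F)cc1`: > 50000 nM

Neither entry is a true number. Compound 1 gives > 50000 nM, which is a limit of the assay. On these data alone, compound 2 gives > 50000 nM, which is also a limit, so its real position in this assay remains unknown. The evidence so far amounts to the limit of > 50000 nM in this assay, at which 2 of the 2 values shown sit.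

The next structure is compound 3 `O/N=C(\COc1cccc2ccccc12)c1ccc(-c2ccccc2)cc1`. The change is phenyl in place of trifluoromethyl on an aromatic carbon, a swap that adds a ring to the molecule.

Within the data shown here, the only measured step is a step that the two limits leave unreadable from compound 1 to compound 2, so it provides no size to carry forward. Compound 2 is the only starting point, with > 50000 nM, so compound 3 is expected to report a limit as well, with no readable shift in either direction in this assay. The expected step is a number no higher from compound 2 to compound 3 (the limit leaves the size open). For compound 3 the estimated value is 50000 nM. The estimated range runs from 20000 nM to 100000 nM.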

Compound 3, half-maximal inhibitory concentration: > 50000 nM
Compound 3: a limit, no number; the forecaster's own chance of this, stated with the estimate: 75%; the middle value sits exactly at the limit.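

In this assay compound 3 gives > 50000 nM, which is a limit of the assay and not a number. Among these compounds, compound 1 and compound 2 also stand at limits, so no step between these three compounds can be read. Still open is the true position of each compound, and whether fluoro, trifluoromethyl or phenyl changes the value at all, with the evidence resting on a single point: the limit of > 50000 nM in this assay, at which 3 of the 3 values shown sit.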